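A few compounds are considered here, and "the series" means these few. Any claim that something is new, unique, unknown or untested is made for them only; others in the source may bear on it.

Measured compounds in an assay on CHO-K1 cells for displacement of a labelled ligand from adenosine receptor A1 (Homo sapiens), read by scintillation counting, with a stated time of 60 min; on this read-out higher numbers stand for weaker inhibition and lower numbers for stronger inhibition:
compound 1 `Nc1nc(N/N=C/c2ccc3ncccc3c2)nc2c1ncn2[C@@H]1O[C@H](CO)[C@@H](O)[C@H]1O` gives 9.8 nM
compound 2 `CCCCc1nc(/C=N/Nc2nc(N)c3ncn([C@@H]4O[C@H](CO)[C@@H](O)[C@H]4O)c3n2)c(Cl)[nH]1` gives 12 nM
compound 3 `CN(C)c1ccc(/C=N/Nc2nc(N)c3ncn([C@@H]4O[C@H](CO)[C@@H](O)[C@H]4O)c3n2)cc1` gives > 10000 nM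

The value of compound 3 is a limit of this assay, not a number (the limit of > 10000 nM in this assay, at which 1 of the 3 values shown sits). Compound 3 therefore stands at the weak end of the three, the two steps that reach it being an at least 1000-fold higher number from compound 1 to compound 3 (3.00 log units; beyond the scatter) and an at least 830-fold higher number from compound 2 to compound 3 (2.92 log units; beyond the scatter), both large. Compound 4 `CCOc1cc(/C=N/Nc2nc(N)c3ncn([C@@H]4O[C@H](CO)[C@@H](O)[C@H]4O)c3n2)ccc1O` differs from compound 3 only at the hydrazone carbon: 3-ethoxy-4-hydroxyphenyl in place of 4-(dimethylamino)phenyl on a carbon with a double bond to nitrogen. For the measured compounds named here, no measured step swaps one phenyl pattern for another; the two large steps only show that compound 3 is far from compounds 1 and 2. The change keeps a phenyl ring, so a return to the potency of compound 1 is not expected, but a move off the limit toward a measurable number is plausible. Expected for compound 4: 3000 nM (range 300 nM to 30000 nM), i.e. an at least 3.3-fold lower number from compound 3 to compound 4 (0.52 log units; beyond the scatter).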

Compound 4, inhibition constant: 6940 nM
The estimate for compound 4 lay 2.3-fold (0.36 log units) below the measured number; the range from low to high includes it.
By their numbers in this assay, from the lowest: compounds 1 and 2 (each within the scatter of the next); then compound 4. At a limit, above all of these: compound 3.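

Compound 3 sits at a limit of this assay, not at a number: the limit of > 10000 nM in this assay, at which 1 of the 4 values shown sits.
With 3-ethoxy-4-hydroxyphenyl on a carbon with a double bond to nitrogen, the series shows an at least 1.4-fold lower number from compound 3 to compound 4 (0.15 log units; that floor lies within the scatter) and so no established gain over 4-(dimethylamino)phenyl.
This phenyl group gives a measurable number yet remains far from the other two groups, with a 580-fold higher number from compound 2 to compound 4 (2.76 log units; beyond the scatter) and a 710-fold higher number from compound 1 to compound 4 (2.85 log units; beyond the scatter).

Open, as far as these compounds go, is whether the hydroxy or the ethoxy alone accounts for the value of compound 4, and whether a phenyl ring bearing a carboxylic acid or a chain longer than ethoxy would come nearer to compound 1 and compound 2.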